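A Pentylphenyl Replaces a Hydroxyphenyl: What to Expect

The source may hold more compounds than are shown below. What is called first, only, known or untested is meant among the compounds shown, and "the series" means these compounds.

Of the compounds shown here, three sharing one core have been tested in a functional assay on HCT-116 cells (Homo sapiens) for antiproliferative activity, read by MTT assay, with a stated time of 72 h; on this read-out lower numbers stand for stronger inhibition and higher numbers for weaker inhibition. Compound 1 `O=C1O/C(=C\Cn2cc(-c3cc(F)cc(F)c3)nn2)C(OCc2ccccc2)=C1OCc1ccccc1` reaches only the limit of this assay, > 100000 nM, and gives no number. Compound 3 `CC(C)(C)OC(=O)N1CCN(C(=S)SCc2cn(C[C@H](O)[C@H]3OC(=O)C(OCc4ccccc4)=C3OCc3ccccc3)nn2)CC1` likewise returns only the limit > 100000 nM. For the measured compounds named here, compound 2 `O=C1O[C@H]([C@@H](O)Cn2cc(-c3cccc(O)c3)nn2)C(OCc2ccccc2)=C1OCc1ccccc1` is the single compound with a measured number, giving 42900 nM in this assay, so it stands alone as the sole figure among the values shown. Two of the three values are limits, namely (the limit of > 100000 nM in this assay, at which 2 of the 3 values shown sit).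

Compound 4 `CCCCCc1ccc(-c2cn(C[C@H](O)[C@H]3OC(=O)C(OCc4ccccc4)=C3OCc3ccccc3)nn2)cc1` differs from compound 2 in one place: 4-pentylphenyl in place of 3-hydroxyphenyl on an aromatic carbon. Going by the values given here, no step between two measured compounds exists to guide the size of this change, so the expectation rests on compound 2 alone. The account expects compound 4 to yield a number rather than a limit, and estimates a modest gain in this assay, a step of a 2.4-fold lower number from compound 2 to compound 4 (0.38 log units; beyond the scatter), which only just crosses the usual scatter. Compound 4 is therefore expected at 18000 nM, with a range from 4000 nM to 100000 nM.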

Compound 4, half-maximal inhibitory concentration: 13800 nM
Compound 4: the middle estimate sits 1.3-fold (0.12 log units) above what was measured; the range from low to high includes it.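

In this assay, for the compounds shown here, the change of 3-hydroxyphenyl to 4-pentylphenyl on this aromatic carbon gives a 3.1-fold lower number from compound 2 to compound 4 (0.49 log units; beyond the scatter), the first step that can be read at this position. It shows that the hydroxyl group is not needed for a measured number here: 4-pentylphenyl, with 0 hydrogen-bond donors and 0 hydrogen-bond acceptors, still gives one, and the step runs towards stronger inhibition. Nothing given here accounts for the size of this step.

Going by these compounds alone, the single step changes both the substituent and its place on the phenyl ring, so the contribution of each cannot be separated. As far as these compounds go, how 4-hydroxyphenyl, 3-pentylphenyl, a longer chain such as octyl or an amine on the phenyl ring would read at this position remains open.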